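The source may report more compounds than this note shows. Statements on the series, on what has been measured and on what is new or still open speak of the compounds shown alone.

Measured compounds:
compound 1, `Nc1nc(NCc2ccc(C(F)(F)F)cc2)nc(-c2ccccc2CO)n1`, in a functional assay on cells for positive allosteric modulation of G-protein coupled receptor 68 (Homo sapiens), read by a luciferase reporter and cAMP accumulation, with a stated time of 30 min, at pH 6.8 and pH 8.3, in the presence of a further agent that is not named here; a higher number here means a more potent compound, by a factor of ten per unit of this negative logarithm, a lower number a less potent compound: 5.03
compound 2, `CC(C)Oc1ccc(CNc2nc(N)nc(-c3ccccc3CO)n2)cc1`, in this assay: 4.99

Both share the same core and differ only in the group on the aromatic carbon of the benzyl ring. The step of a number 0.04 log units lower from compound 1 to compound 2 (within the scatter), isopropoxy in place of trifluoromethyl, stays within the scatter. On the numbers shown compound 2 stands with the lowest of the two values, its nearest neighbour being compound 1, and the gap between them is within the scatter, so no order between them can be claimed.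

Compound 3, `Nc1nc(NCc2ccc(Oc3ccccc3)cc2)nc(-c2ccccc2CO)n1`, has not yet been measured. It differs from compound 2 by phenyl in place of isopropyl on an oxygen on an aromatic ring. Going by the values given here, no measured step describes this exchange of the group on the oxygen; the only step known, from compound 1 to compound 2, concerns the group on the aromatic carbon and was within the scatter. The data give no basis for expecting a step beyond the scatter in this assay, in either direction, so the step expected from compound 2 to compound 3 is a number 0.11 log units higher from compound 2 to compound 3 (within the scatter). Compound 3 is therefore estimated at 5.1, with a range from 4.6 to 5.6.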

Compound 3, negative logarithm of the antagonist equilibrium constant: 5.19
Compound 3: the middle estimate sits 0.09 log units below what was measured; the measured number falls inside the stated range.
By their numbers in this assay, from the lowest: compounds 2, 1 and 3 (each within the scatter of the next).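

In this assay, phenyl in place of isopropyl on an oxygen on an aromatic ring gives a number 0.20 log units higher from compound 2 to compound 3 (within the scatter), so the group on that oxygen can change from one with no ring to a six-membered aromatic ring of carbon only without a step that stands clear of the scatter. Phenoxy in place of trifluoromethyl on an aromatic carbon gives a number 0.16 log units higher from compound 1 to compound 3 (within the scatter), which means that trifluoromethyl, isopropoxy and phenoxy, three quite different groups at this place, now all lie within the scatter of one another, and no order among them can be claimed. Nothing available explains why these exchanges leave the number so little moved.

The compounds shown leave open whether this place tolerates every group or has simply not yet met one that matters, since no step here rises beyond the scatter. An amine or a carboxylic acid on that aromatic carbon, or a longer chain on the oxygen, would be needed to tell whether the number in this assay can move at this place at all.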